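The source may hold more compounds than are shown below. What is called first, only, known or untested is meant among the compounds shown, and "the series" means these compounds.

The series shares a spiro core built around a nitrile-bearing aminopyran, and two members have been tested. Compound 1 has the structure `Cc1ccc(-n2nncc2CN2C(=O)C3(C(C#N)=C(N)Oc4c3c3nc5ccccc5nc3c3ccccc43)c3ccccc32)c(C)c1`. In a functional assay on MCF7 cells (Homo sapiens) for antiproliferative activity, read by MTT assay, with a stated time of 48 h (on this read-out lower numbers stand for stronger inhibition and higher numbers for weaker inhibition), compound 1 gives > 50000 nM, which is a limit of the assay and not a number. Compound 2 has the structure `Cc1cccc(-n2nncc2CN2C(=O)C3(C(C#N)=C(N)Oc4c(N)cc5nc6ccccc6nc5c43)c3ccccc32)c1`. In this assay compound 2 gives > 50000 nM, again a limit rather than a number. Within the data shown here, compound 2 therefore stands at the edge of what this assay can report, and the only evidence on where the series sits is the limit of > 50000 nM in this assay, at which 2 of the 2 values shown sit, so no measured step exists between the two and neither can be ranked against the other.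

Compound 3, not yet measured, has the structure `Cc1ccc(-n2nncc2CN2C(=O)C3(C(C#N)=C(N)Oc4c(N)cc5nc6ccccc6nc5c43)c3ccccc32)cc1C`. It differs from compound 2 by methyl in place of hydrogen on an aromatic carbon; read one bond further out, a 3-methylphenyl becomes a 3,4-dimethylphenyl. With both measured compounds sitting at the limit, a single added methyl is not expected to move this assay beyond the scatter, and the step of a number no higher from compound 2 to compound 3 (the limit leaves the size open) is estimated to be essentially flat. Compound 3 is accordingly expected to give about 50000 nM, within a range of 20000 nM to 100000 nM, most likely reported again only as a limit.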

Compound 3, half-maximal inhibitory concentration: > 50000 nM
Compound 3 was reported as a limit; the forecaster's own chance of this, stated with the estimate: 80%; the middle value sits exactly at the limit.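

In this assay compound 3 gives > 50000 nM, which is a limit and not a number. Compound 2 also stands at a limit, so no step can be read between compound 2 and compound 3: the limit of > 50000 nM in this assay, at which 3 of the 3 values shown sit.

The compounds shown leave open whether any member of the series gives a measurable value in this assay.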